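A few compounds are considered here, and "the series" means these few. Any claim that something is new, unique, unknown or untested is made for them only; others in the source may bear on it.

Working notes on the series: the core is shared and the group on the terminal amide carbonyl varies. In a functional assay on U-937 cells (Homo sapiens) for antiproliferative activity, read by MTT assay, with a stated time of 24 h (a lower number here means a stronger inhibitor, a higher number a weaker inhibitor), compound 1 `CCCCc1oc2ccccc2c1C(=O)c1ccc(OCCCC(=O)N2CCOCC2)cc1`, with morpholin-4-yl on that carbonyl, gives 21400 nM. Compound 2 `CCCCc1oc2ccccc2c1C(=O)c1ccc(OCCCC(=O)NCc2ccccc2)cc1`, with benzylamino, gives 15800 nM, and compound 3 `CCCCc1oc2ccccc2c1C(=O)c1ccc(OCCCC(=O)N[C@@H](C)c2ccccc2)cc1`, with (1-phenylethyl)amino, gives 22400 nM. Compound 3 stands within the scatter of both other numbers. The measured steps are a 1.0-fold higher number from compound 1 to compound 3 (0.02 log units; within the scatter) and a 1.4-fold higher number from compound 2 to compound 3 (0.15 log units; within the scatter), alongside a 1.4-fold lower number from compound 1 to compound 2 (0.13 log units; within the scatter), and all three stay within the scatter.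

Compound 4 `CCCCc1oc2ccccc2c1C(=O)c1ccc(OCCCC(=O)N[C@H](C)c2ccccc2)cc1` is the next case: the two compounds have the same atoms and bonds and differ only in configuration as drawn: 1 of 1 stereo elements differ; a stereocentre at a saturated chain carbon is drawn S in compound 3 and R in compound 4. The stereocentre at a saturated chain carbon is drawn R instead of S, with nothing entering or leaving.

Within the data shown here, no measured pair differs in configuration alone, so the evidence is indirect. The nearest step is the one that adds the methyl on this same carbon, a 1.4-fold higher number from compound 2 to compound 3 (0.15 log units; within the scatter). Even the exchange of the whole amide group, a 1.0-fold higher number from compound 1 to compound 3 (0.02 log units; within the scatter), gives no separation beyond the scatter. On that basis, no step beyond the scatter is expected in this assay, and no direction can be favoured. The expected step is a 1.1-fold lower number from compound 3 to compound 4 (0.03 log units; within the scatter). For compound 4 the estimated value is 21000 nM, with an expected range of 12000 nM to 36000 nM.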

Compound 4, half-maximal inhibitory concentration: 30700 nM
Compound 4: the middle estimate sits 1.5-fold (0.16 log units) below what was measured, within the range that was stated.
By their numbers in this assay, from the lowest: compounds 2, 1, 3 and 4 (each within the scatter of the next).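

Among these compounds, compound 3 and compound 4 form the only pair here that isolates configuration at the saturated chain carbon, and in this assay the change from S to R gives a 1.4-fold higher number from compound 3 to compound 4 (0.14 log units; within the scatter), so this inversion does not separate the two numbers. The pair gives a direct reading of this one change, with no other structural difference to take into account: the fact that compounds 3 and 4 differ only in the configuration as drawn With the R configuration, the added methyl gives a 1.9-fold higher number from compound 2 to compound 4 (0.29 log units; within the scatter) and the exchange of morpholin-4-yl for (1-phenylethyl)amino gives a 1.4-fold higher number from compound 1 to compound 4 (0.16 log units; within the scatter), so neither change moves beyond the scatter in the R form, as was already the case in the S form.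

The compounds shown leave open whether any other group on the terminal amide carbonyl, such as piperazin-1-yl or a hydroxyl that would make a carboxylic acid, gives a step beyond the scatter. They also leave open whether configuration at this carbon would separate the numbers with ethyl in place of methyl.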